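This account rests on a few compounds, and the source may have more. Where it says the series, first, only, none or still open, it means among the compounds named here.

Of the compounds shown here, two built on one shared core have numbers so far in a functional assay on A549 cells (Homo sapiens) for inhibition, read by MTT assay, with a stated time of 48 h; on this read-out higher numbers stand for weaker inhibition and lower numbers for stronger inhibition. Compound 1 (`COc1ccc(N(C)c2nc(C)nc3ccccc23)cc1[Se]C`) gives 11 nM, and compound 2 (`COc1ccc(N(C)c2nc(C)nc3ccccc23)cc1C[Se]C#N`) gives 98 nM, the higher of the two numbers and so the weaker inhibition of the pair. Among the measured compounds shown here, the single measured step between them is an 8.9-fold higher number from compound 1 to compound 2 (0.95 log units; beyond the scatter). The next compound is compound 3 (`COc1ccc(N(C)c2nc(C)nc3ccccc23)cc1OCCN`), and it differs from compound 2 in one place: a group of 4 heavy atoms (2 carbon, 1 nitrogen, 1 oxygen; no ring) in place of a group of 4 heavy atoms (2 carbon, 1 nitrogen, 1 selenium; no ring), on an aromatic carbon. The incoming 2-aminoethoxy group sits on an aromatic carbon, ortho to a methoxy group and meta to a large group. For the measured compounds named here, only the step from compound 1 to compound 2 bears on this change, and it bears indirectly, since no measured compound lacks selenium at this place. That step shows that a change in this group can move the number beyond the scatter, and it was modest in size. A further modest rise is therefore expected, an estimated 2.6-fold higher number from compound 2 to compound 3 (0.41 log units; beyond the scatter). For compound 3 the expected value is 250 nM, with an estimated range from 50 nM to 1500 nM.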

Compound 3, half-maximal inhibitory concentration: 122 nM
Beside the measured number, compound 3's estimate is 2.0-fold (0.31 log units) above it; measured number inside the range.
By their numbers in this assay, from the lowest: compound 1; then compounds 2 and 3 (each within the scatter of the next).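

In this assay, putting 2-aminoethoxy on this aromatic carbon in place of the group holding selenium and a triple bond gives a 1.2-fold higher number from compound 2 to compound 3 (0.10 log units; within the scatter), so the two groups cannot be told apart on this read-out. Selenium is therefore not required at this place for a number in this range, since compound 3 carries oxygen instead and stays within the scatter of compound 2, but neither of these two groups matches the short selenium group of compound 1, as the comparison of 2-aminoethoxy with that group shows in an 11-fold higher number from compound 1 to compound 3 (1.04 log units; beyond the scatter) and places beyond the scatter. No accompanying measurement ties either step to a cause.

From the compounds shown here alone, whether the low number of compound 1, at 11 nM, depends on selenium itself or on the small size of its group stays open, and a methylthio or methoxy group at this place would separate those two readings. Going by these compounds, it is also open how a longer chain ending in an amine, or a 2-hydroxyethoxy group, would compare with 2-aminoethoxy on this same aromatic carbon.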